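Acyl swap on the ring nitrogen of compound 2

This account rests on a few compounds, and the source may have more. Where it says the series, first, only, none or still open, it means among the compounds named here.

Compound 2 `CC(=O)N1c2ccccc2CCC1C(=O)Nc1ccccc1O` gives 50700 nM in a functional assay on ACHN cells (Homo sapiens) for cytotoxicity, read by sulforhodamine B assay, with a stated time of 72 h (a higher number here means a weaker inhibitor of growth, a lower number a stronger inhibitor of growth), the highest number among the values shown; compound 1 `O=C(Nc1cc(C(F)(F)F)cc(C(F)(F)F)c1)C1CCc2ccccc2N1C(=O)c1ccccc1Cl` gives 4700 nM in this assay, a lower number beyond the scatter. Compound 3 `CC(=O)N1c2ccccc2CCC1C(=O)Nc1ccccc1C(F)(F)F` reaches only the limit > 80000 nM in this assay. For the measured compounds named here, the one measured step, an at least 1.5-fold higher number from compound 2 to compound 3 (0.19 log units; that floor lies within the scatter), changes the anilide ring and does not touch the acyl group on the ring nitrogen. Compound 4 `O=C(Nc1ccccc1O)C1CCc2ccccc2N1C(=O)c1cccc(Cl)c1` carries 3-chlorophenyl in place of methyl on a carbonyl carbon. Going by the values given here, no measured step isolates this change; the lower number of compound 1 at 4700 nM, which also carries an aryl carbonyl there, is the only pointer. A decrease is therefore expected, a 4.2-fold lower number from compound 2 to compound 4 (0.63 log units; beyond the scatter), giving compound 4 an estimated 12000 nM in this assay, within 3500 nM to 40000 nM.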

Compound 4, concentration for 50% growth inhibition: 17200 nM
The estimate for compound 4 lay 1.4-fold (0.16 log units) below the measured number; measured number inside the range.
By their numbers in this assay, from the lowest: compound 1; then compound 4; then compound 2. At a limit, above all of these: compound 3.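

The acyl group on the ring nitrogen now has a step of its own in this assay: a 2.9-fold lower number from compound 2 to compound 4 (0.47 log units; beyond the scatter). With the anilide ring held fixed, 3-chlorophenyl in place of methyl on a carbonyl carbon gives a lower number, now read directly rather than inferred from a compound differing in several places. No measured property bears on why the number falls.

From the compounds shown here alone, whether an amine or a carboxylic acid on that aryl ring, or a longer chain on the carbonyl carbon, shifts the number remains open. Also open, going by these compounds, is whether the same swap holds on the anilide ring of compound 3, whose value is a limit.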